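Dimethyl Substitution on the Hydroxycyclohexyl Amine of Compound 1

This account rests on a few compounds, and the source may have more. Where it says the series, first, only, none or still open, it means among the compounds named here.

Measured compounds:
compound 1, `N#Cc1cnc(NCc2cnccc2C(F)(F)F)cc1N[C@H]1CC[C@H](O)CC1`: 6500 nM
compound 2, `N#Cc1cnc(NCc2ccccc2C(F)(F)F)cc1N[C@H]1C[C@H](C(N)=O)C1`: > 10000 nM

Compound 1 carries a 4-hydroxycyclohexyl group on a nitrogen on an aromatic ring of the shared core. For the measured compounds named here, in an assay on isolated protein for inhibition of protein kinase C delta type (Homo sapiens), read by TR-FRET, with a stated time of 2 h (a lower number here means a stronger inhibitor, a higher number a weaker inhibitor), compound 1 gives 6500 nM, the only finished number in this set. Compound 2, which pairs a different ring on that nitrogen with a different aromatic group elsewhere, gives in this assay only > 10000 nM, a limit of the assay rather than a number, as the limit of > 10000 nM in this assay, at which 1 of the 2 values shown sits, records. Compound 3, `CC1(C)C[C@@H](Nc2cc(NCc3cnccc3C(F)(F)F)ncc2C#N)CC[C@@H]1O`, differs from compound 1 in one place: 4-hydroxy-3,3-dimethylcyclohexyl in place of 4-hydroxycyclohexyl on a nitrogen on an aromatic ring. Going by the values given here, no measured pair shows what such a change does, so the step is expected to stay within the scatter, in either direction. Compound 3 is therefore estimated at 5500 nM, within 1800 nM to 15000 nM, a step of a 1.2-fold lower number from compound 1 to compound 3 (0.07 log units; within the scatter) that is expected to be small.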

Compound 3, half-maximal inhibitory concentration: 2400 nM
The estimate for compound 3 lay 2.3-fold (0.36 log units) above the measured number; the measured number falls inside the stated range.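

In this assay, replacing 4-hydroxycyclohexyl with 4-hydroxy-3,3-dimethylcyclohexyl on a nitrogen on an aromatic ring gives a 2.7-fold lower number from compound 1 to compound 3 (0.43 log units; beyond the scatter). For the compounds shown here, this is the first measured pair at this position, and it shows that the number there responds to a change in the ring substituent even when the hydroxy group and the two defined stereocentres are kept. Nothing given here bears on why the number falls with this change.

The compounds shown leave open whether both methyl groups are needed or a single methyl group would give the same step. They also leave open how a larger group such as gem-diethyl, or an amine in place of the hydroxy group, would read on this ring.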